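Adding a Methyl Group to Compound 3: What to Expect

The compounds below may be only part of what the source reports. "The series", "measured", "known", "first", "only" and "open" are said of these compounds alone.

Compound 3, with structure `Nc1nc(-c2ccc3ccccc3c2)cn1/N=C/c1cc2ccccc2nc1Cl`, stands at > 50000 nM in a functional assay on HCT-116 cells (Homo sapiens) for cytotoxicity, read by MTT assay, with a stated time of 48 h; on this read-out lower numbers stand for stronger inhibition and higher numbers for weaker inhibition; that value is a limit of the assay rather than a measured number. Compound 1, `COc1ccc(-c2cn(/N=C/c3cc4cc(C)ccc4nc3Cl)c(N)n2)cc1`, gives > 50000 nM in this assay, again a limit. Compound 2, `Cc1ccc2nc(Cl)c(/C=N/n3cc(-c4ccc(Br)cc4)nc3N)cc2c1`, gives 49900 nM in this assay. The picture is shaped by the limit of > 50000 nM in this assay, at which 2 of the 3 values shown sit. Compound 4, `Cc1ccc2nc(Cl)c(/C=N/n3cc(-c4ccc5ccccc5c4)nc3N)cc2c1`, differs from compound 3 by methyl in place of hydrogen on an aromatic carbon. Among the measured compounds shown here, the only measured step, a number no higher from compound 1 to compound 2 (the limit leaves the size open), changes a different ring, and its size is hidden by a limit, so no measured step follows a methyl for hydrogen on the ring carrying this change. Accordingly the step of a number no higher from compound 3 to compound 4 (the limit leaves the size open) is expected to stay within the usual scatter. Compound 4 is therefore estimated at 50000 nM, between 25000 nM and 100000 nM, most likely reported again as a limit.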

Compound 4, half-maximal inhibitory concentration: 27400 nM
Compound 4: middle estimate off by 1.8-fold (0.26 log units), on the high side, within the range that was stated.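

The methyl on this ring now has a step that can be read: an at least 1.8-fold lower number from compound 3 to compound 4 (0.26 log units; that floor lies within the scatter). As far as these compounds go, its true size stays open because compound 3 stands at a limit: the limit of > 50000 nM in this assay, at which 2 of the 4 values shown sit. With the methyl kept, changing the aryl group gives a 1.8-fold lower number from compound 2 to compound 4 (0.26 log units; within the scatter) and an at least 1.8-fold lower number from compound 1 to compound 4 (0.26 log units; that floor lies within the scatter), so neither step shows naphthalen-2-yl standing clearly apart from 4-bromophenyl or 4-methoxyphenyl.

From the compounds shown here alone, whether an amine or an ethyl chain in place of the methyl on this carbon would move the number remains open. So does whether the methyl has any effect alongside the other aryl groups.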